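The compounds below may be only part of what the source reports. "The series", "measured", "known", "first", "only" and "open" are said of these compounds alone.

All three measured compounds share the same core, carrying a short chain that ends in a different group each time. In a functional assay on MDA-MB-468 cells (Homo sapiens) for cytotoxicity, read by resazurin assay, with a stated time of 72 h (a higher number here means a weaker inhibitor, a lower number a stronger inhibitor), compound 1, `O=S(=O)(O)CCCSC(=S)NCc1cccnc1`, gives 11100 nM. Compound 2, `S=C(NCc1cccnc1)SCCc1nnn[nH]1`, gives only a limit of > 100000 nM in this assay, so no number is known for it. Compound 3, `COc1ccc(-c2nnc(CCSC(=S)NCc3cccnc3)o2)cc1`, gives 5220 nM in this assay, the lowest of the two numbers; compound 1 is nearest, and the gap between compound 3 and compound 1 is beyond the usual scatter.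

For the measured compounds named here, the one step measured in a single place is an at least 9.0-fold higher number from compound 1 to compound 2 (0.95 log units; beyond the scatter); its size is bounded by the limit of > 100000 nM in this assay, at which 1 of the 3 values shown sits, so only a lower bound on the weakening is known.

Compound 4, `S=C(NCc1cccnc1)SCCc1nnc(-c2cnccn2)o1`, differs from compound 3 by pyrazin-2-yl in place of 4-methoxyphenyl on an aromatic carbon. The measured step concerns the group at the chain end rather than the aromatic group on the five-membered ring, so it gives no direct guide to this change. The expected step of a 1.4-fold higher number from compound 3 to compound 4 (0.16 log units; within the scatter) is small, within or only slightly beyond the scatter, in the direction of a weaker inhibitor. Compound 4 is therefore estimated at 7500 nM in this assay, in the range 2500 nM to 22000 nM.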

Compound 4, half-maximal inhibitory concentration: 1710 nM
For compound 4 the middle estimate is 4.4-fold (0.64 log units) above the measured one, and the stated range ends above it.
By their numbers in this assay, from the lowest: compound 4; then compound 3; then compound 1. At a limit, above all of these: compound 2.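

In this assay, for the compounds shown here, the swap of 4-methoxyphenyl for pyrazin-2-yl brings a 3.1-fold lower number from compound 3 to compound 4 (0.48 log units; beyond the scatter) and so shows that the aromatic group on the five-membered ring also shifts the number, whereas the one earlier step concerned only the group at the chain end. The change in this position runs toward a stronger inhibitor even though the entering group has fewer heavy atoms, so the larger carbon-only ring with its methoxy group is not required for activity here. One swap alters the ring atoms, the size of the group and the count of hydrogen-bond acceptors together, so the result cannot separate these changes, and no measurement shown here explains why the number falls.

Still open, going by these compounds, is how much of the gain belongs to the ring nitrogens, which a plain phenyl or a pyridin-2-yl group in the same position could help to separate. Also open, on these data alone, is whether the gain would persist with an amine on the ring or with a longer chain between the sulfur and the five-membered ring.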